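Replacing furan-2-yl with phenyl in compound 2

The compounds below may be only part of what the source reports. "The series", "measured", "known", "first", "only" and "open" are said of these compounds alone.

Compound 1 `C#Cc1cn([C@@H]2O[C@H](CO)[C@@H](O)[C@H]2O)c2ncnc(OC)c12`: 8160 nM
Compound 2 `CNc1ncnc2c1c(-c1ccco1)cn2[C@@H]1O[C@H](CO)[C@@H](O)[C@H]1O`: 2570 nM

In a functional assay on A549 cells (Homo sapiens), read by MTT assay, with a stated time of 72 h (on this read-out lower numbers stand for stronger inhibition and higher numbers for weaker inhibition), only these two compounds have been measured. Compound 2, at 2570 nM, holds the lower of the two numbers, and the gap to compound 1 lies beyond the scatter. The two compounds differ in more than one place, so their values do not show what a single exchange does.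

Compound 3 `CNc1ncnc2c1c(-c1ccccc1)cn2[C@@H]1O[C@H](CO)[C@@H](O)[C@H]1O` has not yet been measured in this assay. It departs from compound 2 by one exchange, phenyl in place of furan-2-yl on an aromatic carbon. Among the compounds with values here, no measured pair shows this exchange directly, so the expectation is tentative. A modest move toward weaker inhibition is expected, only slightly beyond the scatter, with the estimated step being a 2.3-fold higher number from compound 2 to compound 3 (0.37 log units; beyond the scatter). For compound 3 the estimated value is 6000 nM, within an expected range from 1800 nM to 20000 nM.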

Compound 3, half-maximal inhibitory concentration: > 20000 nM
Compound 3 ended at the assay's limit; the forecaster's own chance of this, stated with the estimate: 25%; middle value at least 3.3-fold (0.52 log units) away from the limit.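

In this assay compound 3 reads > 20000 nM, which is a limit of the assay and not a number. Within the data shown here, on this aromatic carbon of the five-membered aromatic ring, phenyl in place of furan-2-yl gives an at least 7.7-fold higher number from compound 2 to compound 3 (0.89 log units; beyond the scatter), the first single exchange that can be read, and it shows that the two aromatic rings are not interchangeable at this position. On these data alone, only the lower end of the step can be read, and its full size stays unknown: the limit of > 20000 nM in this assay, at which 1 of the 3 values shown sits.

As far as these compounds go, whether a thiophen-2-yl or pyridin-2-yl ring at this place would read nearer to compound 2 or to compound 3 stays open. So does the effect of an amine or a longer chain there, and whether the same exchange would act alike on the other groups of the shared core.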